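From azetidin-1-yl to dimethylamino on the carbonyl carbon

The source may report more compounds than this note shows. Statements on the series, on what has been measured and on what is new or still open speak of the compounds shown alone.

Measured in a functional assay on MCF7 cells (Homo sapiens) for antiproliferative activity, read by CCK-8 assay, with a stated time of 48 h; a higher number here means a weaker inhibitor, a lower number a stronger inhibitor:
- compound 1 `CN(C)C(=O)/C=C/CNCCOc1ccc(Oc2c(-c3ccc(F)cc3)sc3cc(O)ccc23)cc1`: 13800 nM
- compound 2 `O=C(/C=C/CN1CC(Oc2ccc(Oc3c(-c4ccc(F)cc4)sc4cc(O)ccc34)cc2)C1)N1CCCC1`: 8450 nM
- compound 3 `O=C(/C=C/CN1CC(Oc2ccc(Oc3c(-c4ccc(F)cc4)sc4cc(O)ccc34)cc2)C1)N1CCC1`: > 25000 nM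

The entry for compound 3 is a limit and not a number. Its place is the limit of > 25000 nM in this assay, at which 1 of the 3 values shown sits. Compound 4 `CN(C)C(=O)/C=C/CN1CC(Oc2ccc(Oc3c(-c4ccc(F)cc4)sc4cc(O)ccc34)cc2)C1` is unmeasured and carries dimethylamino in place of azetidin-1-yl on a carbonyl carbon. For the measured compounds named here, the one measured step at this place is an at least 2.9-fold higher number from compound 2 to compound 3 (0.47 log units; beyond the scatter), beyond the scatter, with azetidin-1-yl as the entering group. Compound 1, which differs elsewhere but also carries dimethylamino there, gives 13800 nM. A return to a lower number is therefore expected in this assay, of at least modest size. The estimated step is an at least 1.9-fold lower number from compound 3 to compound 4 (0.28 log units; that floor lies within the scatter). Compound 4 is expected at 13000 nM, with an estimated range of 6000 nM to 28000 nM.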

Compound 4, half-maximal inhibitory concentration: 22300 nM
Compound 4: the middle estimate sits 1.7-fold (0.23 log units) below what was measured; the measured number falls inside the stated range.
By their numbers in this assay, from the lowest: compounds 2, 1 and 4 (each within the scatter of the next, the first and the last beyond it). At a limit, above all of these: compound 3.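

In this assay, dimethylamino also falls behind pyrrolidin-1-yl on the carbonyl carbon, with a 2.6-fold higher number from compound 2 to compound 4 (0.42 log units; beyond the scatter), so both replacements shown raise the number beyond the scatter. With dimethylamino held constant, the change of side chain gives a 1.6-fold higher number from compound 1 to compound 4 (0.21 log units; within the scatter), and no change can be read from it. The entry for compound 3 is only a limit, and an at least 1.1-fold lower number from compound 3 to compound 4 (0.04 log units; that floor lies within the scatter) does not set dimethylamino apart from azetidin-1-yl.

On these data alone, it remains open whether piperidin-1-yl or morpholin-4-yl on the carbonyl carbon would match pyrrolidin-1-yl. As far as these compounds go, it is also open whether pyrrolidin-1-yl would keep its lower number on the side chain of compound 1.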